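Removing the acetyl from compound 2: an expected outcome

The source may hold more compounds than are shown below. What is called first, only, known or untested is meant among the compounds shown, and "the series" means these compounds.

Measured so far:
compound 1 `COc1ccc(C2C(O)C(=O)N2c2cc(OC)c(OC)c(OC)c2)cc1` gives 33 nM
compound 2 `COc1ccc(N2C(=O)C(OC(C)=O)C2c2cc(OC)c(OC)c(OC)c2)cc1` gives > 1000 nM

Compound 1 sits comfortably in the potent range of a functional assay on IMR-32 cells (Homo sapiens) for cytotoxicity; on this read-out higher numbers stand for weaker inhibition and lower numbers for stronger inhibition. For compound 2 the value is not a number but a limit of this assay, (the limit of > 1000 nM in this assay, at which 1 of the 2 values shown sits), so compound 2 stands at the weak end of what has been measured, and how far beyond cannot be told. Compound 3 `COc1ccc(N2C(=O)C(O)C2c2cc(OC)c(OC)c(OC)c2)cc1` has not yet been measured. It differs from compound 2 in one place: hydrogen in place of acetyl on an oxygen on a saturated carbon, turning acetoxy into hydroxy. Within the data shown here, no measured pair covers this change. Compound 1 also carries a free hydroxy, though its aryl groups sit differently, so it offers no direct guide. The step of an at least 1.6-fold lower number from compound 2 to compound 3 (0.22 log units; that floor lies within the scatter) is expected to go toward stronger inhibition but is uncertain. Compound 3 is estimated at 600 nM, within 60 nM to 5000 nM.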

Compound 3, half-maximal inhibitory concentration: > 1000 nM
Compound 3: only a limit was reported; the forecaster's own chance of this, stated with the estimate: 40%; at least 1.6-fold (0.22 log units) between middle value and limit.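

Among these compounds, compound 2 and compound 3 both sit at a limit of this assay rather than at a number, so no step between them can be read: the limit of > 1000 nM in this assay, at which 2 of the 3 values shown sit. From the compounds shown here alone, whether turning acetoxy into hydroxy changes inhibition at all, and in which direction, stays open.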